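Carbonyl substituent change on the ring nitrogen carbamate

The source may report more compounds than this note shows. Statements on the series, on what has been measured and on what is new or still open speak of the compounds shown alone.

Among the measured compounds shown here, compound 2 `Cc1nc(S(C)(=O)=O)ccc1Oc1ncnc(OC2CCN(C(=O)OC3(C(F)(F)F)CCC3)CC2)c1F` gives 63.3 nM in a functional assay on isolated protein for inhibition of Glucose-dependent insulinotropic receptor (Rattus norvegicus), read by HTRF and cAMP accumulation (on this read-out lower numbers stand for an effect already at smaller amounts and higher numbers for an effect only at larger amounts of compound), and holds the lowest of the two numbers measured so far; its nearest neighbour is compound 1 `Cc1nc(S(C)(=O)=O)ccc1Oc1ncnc(OC2CCN(C(=O)O[C@H](C)C(F)(F)F)CC2)c1F` with 110 nM, and a 1.7-fold lower number from compound 1 to compound 2 (0.24 log units; within the scatter) lies within the scatter. Compound 3 `Cc1nc(S(C)(=O)=O)ccc1Oc1ncnc(OC2CCN(C(=O)C3(F)CCC3)CC2)c1F` is not yet measured. It differs from compound 2 in a group of 5 heavy atoms (4 carbon, 1 fluorine; one four-membered non-aromatic ring of carbon only) in place of a group of 9 heavy atoms (5 carbon, 1 oxygen, 3 fluorine; one four-membered non-aromatic ring of carbon only), on a carbonyl carbon. For the measured compounds named here, the only measured step, a 1.7-fold lower number from compound 1 to compound 2 (0.24 log units; within the scatter), exchanged the group sitting on the oxygen next to the carbonyl group and kept that oxygen; the change to compound 3 removes that oxygen together with the trifluoromethyl, so no measured step bears directly on it. With nothing to guide direction, no step beyond the scatter is expected, but the range must be wide. Compound 3 is expected to give 120 nM, between 30 nM and 500 nM. This corresponds to an expected step of a 1.9-fold higher number from compound 2 to compound 3 (0.28 log units; within the scatter).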

Compound 3, half-maximal effective concentration: 123 nM
For compound 3 the middle estimate is 1.0-fold (0.01 log units) below the measured one; measured number inside the range.
By their numbers in this assay, from the lowest: compounds 2, 1 and 3 (each within the scatter of the next).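

In this assay the group on the carbonyl carbon can lose both the oxygen and the trifluoromethyl with no step beyond the scatter, as shown by the exchange from the cyclobutyl carbamate (a 1.9-fold higher number from compound 2 to compound 3 (0.29 log units; within the scatter)) and from the open-chain carbamate (a 1.1-fold higher number from compound 1 to compound 3 (0.05 log units; within the scatter)). This place therefore accepts the group of 5 heavy atoms as well as the groups of 7 and 9 heavy atoms, and the read-out does not separate the carbamates from this amide-type compound. No supporting data are available to explain this result.

The compounds shown do not separate the contribution of the oxygen from that of the trifluoromethyl, nor show what the ring fluorine contributes. Also open, from the compounds shown here alone, is how a plain cyclobutyl, a secondary amine forming a urea or a longer alkyl chain would read at this carbonyl carbon.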